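A Fluorophenyl Amide in Place of a Spirocyclic Acyl Group

This account rests on a few compounds, and the source may have more. Where it says the series, first, only, none or still open, it means among the compounds named here.

Compound 1, `O=C([C@H]1CC2CCC1C2)N1CC(c2nc(-c3ccccc3)no2)C1`, gives 120 nM in an assay on HEK293 cells for positive allosteric modulation of metabotropic glutamate receptor 5 (Homo sapiens), read by FLIPR; on this read-out higher numbers stand for an effect only at larger amounts of compound and lower numbers for an effect already at smaller amounts.
Compound 2, `O=C(C1CCC2(CCC2)CC1)N1CC(c2nc(-c3cccc(Cl)c3)no2)C1`, gives 1100 nM in this assay.
Compound 3, `O=S(=O)(c1ccc(Cl)cc1)N1CC(c2nc(-c3cccc(Cl)c3)no2)C1`, reaches only a limit of the assay, > 10000 nM, in this assay.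

Among the two numbers, compound 2 stands at the highest; its nearest neighbour is compound 1, whose number is lower by a gap beyond the usual scatter. The third value is a limit and not a number.

Compound 4, `O=C(c1cccc(F)c1)N1CC(c2nc(-c3cccc(Cl)c3)no2)C1`, differs from compound 2 in one place: a group of 7 heavy atoms (6 carbon, 1 fluorine; one six-membered aromatic ring of carbon only) in place of a group of 9 heavy atoms (9 carbon; one four-membered non-aromatic ring of carbon only, one six-membered non-aromatic ring of carbon only), on a carbonyl carbon.

Within the data shown here, no measured pair matches this change, so the expectation rests on the spread of the numbers alone. In this assay the step of a 2.4-fold lower number from compound 2 to compound 4 (0.39 log units; beyond the scatter) is expected to move toward a lower number, beyond the scatter but short of the gap to compound 1. Compound 4 is estimated at 450 nM, within 100 nM to 3000 nM.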

Compound 4, half-maximal effective concentration: > 10000 nM
Compound 4 gave a limit, no number (the forecaster's own chance of this, stated with the estimate: 15%); middle value at least 22-fold (1.34 log units) away from the limit.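

At the carbonyl carbon, 3-fluorophenyl in place of the non-aromatic group of 9 heavy atoms gives an at least 9.0-fold higher number from compound 2 to compound 4 (0.95 log units; beyond the scatter) in this assay. Among these compounds, this is the first step read at this position, and it shows that the number depends strongly on the group placed there. The value of compound 4 is a limit of the assay and not a number: the limit of > 10000 nM in this assay, at which 2 of the 4 values shown sit.

The compounds shown leave open whether the aromatic ring or the fluorine accounts for this step. On these data alone, how an unsubstituted phenyl, a cyclohexyl or a pyridyl group would read at this carbonyl carbon also remains open.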